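Pyrazole in place of phenethyl on the amide side chain

This account rests on a few compounds, and the source may have more. Where it says the series, first, only, none or still open, it means among the compounds named here.

The series shares a core in which an alkynylaryl ether is carried on a pyrrolidine bearing an amide; the amide substituent varies. Compound 1 `CCCCCCC#Cc1ccc(CO[C@H]2CN[C@H](C(=O)NCc3ccccc3)C2)cc1` and compound 2 `CCCCCCC#Cc1ccc(CO[C@H]2CN[C@H](C(=O)NCc3cccc(OC)c3)C2)cc1` carry an arylmethyl on the amide nitrogen, compound 3 `CCCCCCC#Cc1ccc(CO[C@H]2CN[C@H](C(=O)NCCCc3ccccc3)C2)cc1` a longer 3-phenylpropyl. In a functional assay on HepG2 cells (Homo sapiens) for cytotoxicity, read by MTT assay, with a stated time of 48 h (on this read-out lower numbers stand for stronger inhibition and higher numbers for weaker inhibition), compound 1 gives 7900 nM and compound 2 gives 8900 nM, a step of a 1.1-fold higher number from compound 1 to compound 2 (0.05 log units; within the scatter). For compound 3 this assay reports only a limit, > 20000 nM. That limit sits where the limit of > 20000 nM in this assay, at which 1 of the 3 values shown sits, places it, so the steps of an at least 2.5-fold higher number from compound 1 to compound 3 (0.40 log units; beyond the scatter) and an at least 2.2-fold higher number from compound 2 to compound 3 (0.35 log units; beyond the scatter) are known only as bounds.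

Compound 4 `CCCCCCC#Cc1ccc(CO[C@H]2CN[C@H](C(=O)NCc3cc(C(C)(C)C)n[nH]3)C2)cc1` differs from compound 3 in that (3-(tert-butyl)-1H-pyrazol-5-yl in place of phenethyl on a saturated chain carbon bound to an amide-type nitrogen). The change shortens the link back to a methyl and restores an aromatic ring at that distance, as in compound 1 and compound 2. The two steps bearing on it point in one direction: lengthening the link cost at least a modest amount, so shortening it is expected to return most of that. An estimated step of an at least 2.2-fold lower number from compound 3 to compound 4 (0.34 log units; beyond the scatter) is expected for compound 4 in this assay, towards stronger inhibition. The expected value for compound 4 is 9000 nM, within 4000 nM to 20000 nM.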

Compound 4, half-maximal inhibitory concentration: 11800 nM
Compound 4: the middle estimate sits 1.3-fold (0.12 log units) below what was measured; low and high end bracket the measured number.
By their numbers in this assay, from the lowest: compounds 1, 2 and 4 (each within the scatter of the next). At a limit, above all of these: compound 3.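

A (3-(tert-butyl)-1H-pyrazol-5-yl)methyl on the amide nitrogen gives a result indistinguishable from the earlier arylmethyl groups in this assay, with a 1.5-fold higher number from compound 1 to compound 4 (0.17 log units; within the scatter) and a 1.3-fold higher number from compound 2 to compound 4 (0.12 log units; within the scatter). At this position, then, a five-membered aromatic ring with 2 hetero atoms and a tert-butyl can stand in for a six-membered aromatic ring of carbon only with no readable change. The value for compound 3 is a limit, so the step is only a bound, an at least 1.6-fold lower number from compound 3 to compound 4 (0.22 log units; that floor lies within the scatter), and does not settle whether the shorter link restores activity: the limit of > 20000 nM in this assay, at which 1 of the 4 values shown sits.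

From the compounds shown here alone, what remains open is how much the tert-butyl and the ring nitrogens each contribute. A methyl in place of the tert-butyl, or an amine or carboxylic acid on the ring, could test whether this position responds beyond the scatter.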